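A few compounds are considered here, and "the series" means these few. Any claim that something is new, unique, unknown or untested is made for them only; others in the source may bear on it.

The measured compounds: compound 1 `COc1ccc(-c2nc(/N=C(\N)[N+]3(C)CCCCC3)sc2-c2ccc(OC)cc2)cc1`, which in a functional assay (aorta) with Rattus norvegicus as the target (on this read-out higher numbers stand for an effect only at larger amounts of compound and lower numbers for an effect already at smaller amounts), gives 21 uM; compound 2 `COc1ccc(-c2nc(CN(C)C)sc2-c2ccc(OC)cc2)cc1`, which in this assay gives 8.4 uM; compound 3 `CCN(CC)C(=O)c1nc(-c2ccc(OC)cc2)c(-c2ccc(OC)cc2)s1`, which in this assay gives 14 uM.

Compound 3 stands second highest of these three numbers, and the steps of a 1.5-fold lower number from compound 1 to compound 3 (0.18 log units; within the scatter) and a 1.7-fold higher number from compound 2 to compound 3 (0.22 log units; within the scatter) both lie within the scatter, so it cannot be ordered against either neighbour. Compound 4 `COc1ccc(-c2nc(C3=CCN(C)CC3)sc2-c2ccc(OC)cc2)cc1` differs from compound 3 by a group of 7 heavy atoms (6 carbon, 1 nitrogen; one six-membered non-aromatic ring with 1 hetero atom) in place of a group of 7 heavy atoms (5 carbon, 1 nitrogen, 1 oxygen; no ring), on an aromatic carbon. Among the measured compounds shown here, the only step beyond the scatter, a 2.5-fold lower number from compound 1 to compound 2 (0.40 log units; beyond the scatter), went with the loss of a six-membered non-aromatic ring with 1 hetero atom; here such a ring enters, which points to a small rise, though compound 3, without a ring, already sits within the scatter of compound 1. Compound 4 is therefore expected to show a 1.1-fold higher number from compound 3 to compound 4 (0.06 log units; within the scatter), with an estimate of 16 uM and a range of 6 uM to 40 uM.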

Compound 4, concentration for half-maximal effect: 5.9 uM
Compound 4: middle estimate off by 2.7-fold (0.43 log units), on the high side; measured number outside the range, below it.
By their numbers in this assay, from the lowest: compounds 4, 2, 3 and 1 (each within the scatter of the next, the first and the last beyond it).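

Among the compounds shown here, on this aromatic carbon, replacing diethylcarbamoyl with the new ring group gives a 2.4-fold lower number from compound 3 to compound 4 (0.38 log units; beyond the scatter) in this assay, the first step beyond the scatter that does not start from compound 1. A six-membered non-aromatic ring with 1 hetero atom does not settle the outcome by itself, since compound 1 also carries one and the data show a 3.6-fold lower number from compound 1 to compound 4 (0.55 log units; beyond the scatter). The ring group also cannot be ordered against (dimethylamino)methyl, given a 1.4-fold lower number from compound 2 to compound 4 (0.15 log units; within the scatter), and nothing measured accounts for these steps. The compounds shown leave open whether the ring double bond matters, as a saturated N-methylpiperidine is not among them. They also leave open how a carboxylic acid would behave here.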